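From methoxy to nitro: working notes on compound 3

The source may hold more compounds than are shown below. What is called first, only, known or untested is meant among the compounds shown, and "the series" means these compounds.

Measured in an ADME assay on Vero cells (Chlorocebus sabaeus) for cytotoxicity; on this read-out higher numbers stand for lower toxicity in this test and lower numbers for higher toxicity in this test:
- compound 1 `COc1ccc(-c2nc3cc(C(F)(F)F)ccc3[nH]2)c(OC)c1`: > 100000 nM (a limit of the assay, not a number)
- compound 2 `COc1ccc(-c2nc3cc(C(F)(F)F)ccc3[nH]2)c(OC)c1OC`: 70000 nM

Compound 1 stands at the limit of > 100000 nM in this assay, at which 1 of the 2 values shown sits, so its position is known only as a limit.

Compound 3 `COc1ccc(-c2nc3cc(C(F)(F)F)ccc3[nH]2)c([N+](=O)[O-])c1` is the next case, with nitro in place of methoxy on an aromatic carbon. The group that changes is the methoxy ortho to a large group.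

Going by the values given here, the one measured step, an at least 1.4-fold lower number from compound 1 to compound 2 (0.15 log units; that floor lies within the scatter), is a different change, methoxy in place of hydrogen, so it bears on this case only loosely. Among the compounds with values here, no measured step covers nitro. On the strength of that single step, only a small move towards lower numbers in this assay is expected, or none beyond the scatter, and a second limit reading would not surprise. The expected step is an at least 1.4-fold lower number from compound 1 to compound 3 (0.15 log units; that floor lies within the scatter). The estimate for compound 3 is 70000 nM, with an expected range of 20000 nM to 100000 nM.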

Compound 3, half-maximal cytotoxic concentration: 20000 nM
Compound 3: middle estimate off by 3.5-fold (0.54 log units), on the high side; low and high end bracket the measured number.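

In this assay the change from methoxy to nitro on this aromatic carbon gives an at least 5.0-fold lower number from compound 1 to compound 3 (0.69 log units; beyond the scatter) and so shows that this position, ortho to a large group, can move the read-out towards higher toxicity in this test. The earlier step of an at least 1.4-fold lower number from compound 1 to compound 2 (0.15 log units; that floor lies within the scatter) concerned a different change, which makes this the first step shown to lie beyond the scatter. Its size is a floor and not a full measure, because compound 1 is held only as a limit: the limit of > 100000 nM in this assay, at which 1 of the 3 values shown sits.

The compounds shown do not separate the arrival of nitro from the departure of methoxy at this position. A fluorine, an amine or a carboxylic acid on the same carbon would show whether the lower number is particular to nitro.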